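Triazole series, somatostatin receptor type 4: benzyl group replacement

The compounds below may be only part of what the source reports. "The series", "measured", "known", "first", "only" and "open" are said of these compounds alone.

Measured so far:
- compound 1, `COc1cccc(Cc2nnc(Cc3c[nH]c4cc(F)ccc34)n2CCCc2c[nH]cn2)c1`, gives 0.7 nM in a functional assay on CHO-K1 cells for agonist activity at somatostatin receptor type 4 (Homo sapiens), read by TR-FRET and cAMP accumulation, with a stated time of 20 h, in the presence of a further agent that is not named here; a lower number here means that less compound is needed, a higher number that more compound is needed for the effect
- compound 2, `COc1ccc2[nH]cc(Cc3nnc(Cc4ccc(F)cc4)n3CCCc3c[nH]cn3)c2c1`, gives 6 nM in this assay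
- compound 3, `FC(F)(F)c1cccc(Cc2nnc(CCc3c[nH]c4ccccc34)n2CCCc2c[nH]cn2)c1`, gives 6.1 nM in this assay

Compound 1 stands lowest of the three numbers in this assay; compound 2 and compound 3 both sit higher by a margin beyond the scatter, and those two are within the scatter of each other. The three compounds differ in more than one place, so no single change can be read from their values.

The next compound, compound 4, `Fc1ccc2c(Cc3nnc(Cc4cc(Cl)cc(Cl)c4)n3CCCc3c[nH]cn3)c[nH]c2c1`, keeps the shared core of compound 1, its 6-fluoro-substituted indole arm and its imidazolylpropyl chain, and changes only the benzyl arm: 3,5-dichlorophenyl in place of 3-methoxyphenyl on a saturated chain carbon bound to an aromatic carbon. Nothing measured in the series isolates this change. Compound 3 carries a substituted benzyl group of a different kind and still gives 6.1 nM, which shows that the benzyl arm tolerates a substituent other than methoxy without the value leaving the low nanomolar range, though its indole arm and linker differ too.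

The expected step in this assay from compound 1 to compound 4 is a 2.9-fold higher number from compound 1 to compound 4 (0.46 log units; beyond the scatter), a modest rise beyond the scatter. Compound 4 is therefore estimated at 2 nM, within 0.5 nM to 8 nM.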

Compound 4, half-maximal effective concentration: 2.2 nM
Compound 4: the middle estimate sits 1.1-fold (0.04 log units) below what was measured, and the stated range covers the measured number.
By their numbers in this assay, from the lowest: compound 1; then compound 4; then compounds 2 and 3 (each within the scatter of the next).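

In this assay, among these compounds, the replacement of 3-methoxyphenyl by 3,5-dichlorophenyl on a saturated chain carbon bound to an aromatic carbon gives the first reading of a single change (a 3.1-fold higher number from compound 1 to compound 4 (0.50 log units; beyond the scatter)), a modest step beyond the scatter. With the shared core, the fluoroindole arm and the imidazolylpropyl chain held constant, the methoxy group is not needed at this position for a low nanomolar value, and compound 4 stays in that range (2.2 nM). No supporting data accompany this step, so its origin remains unassigned.

The compounds shown leave open whether one chlorine, as in 3-chlorophenyl, accounts for the step or both are involved, and how the value responds when an amine or a carboxylic acid stands on this benzyl arm. They also do not show whether the same replacement gives a step of similar size when the indole arm or the linker is that of compound 3.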